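Chloro to fluoro on the shared core

The compounds below may be only part of what the source reports. "The series", "measured", "known", "first", "only" and "open" are said of these compounds alone.

Measured so far:
compound 1 `CC1(C)CC(NC(=S)Nc2ccc([N+](=O)[O-])cc2)c2cc(Br)ccc2O1`: 3000 nM
compound 2 `CC1(C)CC(NC(=S)Nc2ccc([N+](=O)[O-])cc2)c2cc(Cl)ccc2O1`: 3000 nM

In a functional assay on B16-F10 cells (Mus musculus) for inhibition, read by MTT assay, with a stated time of 72 h (a higher number here means a weaker inhibitor, a lower number a stronger inhibitor), compound 2 stands at 3000 nM, level with compound 1. Compound 3 `CC1(C)CC(NC(=S)Nc2ccc([N+](=O)[O-])cc2)c2cc(F)ccc2O1` carries fluoro in place of chloro on an aromatic carbon. Among the measured compounds shown here, one measured step bears on this change, the exchange of bromo for chloro at the same place: no change at the digits printed from compound 1 to compound 2 (within the scatter). For the measured compounds named here, that single step gives no direction, and no fluoro compound has been measured, so no step beyond the scatter is expected in this assay. The expected step is a 1.2-fold higher number from compound 2 to compound 3 (0.07 log units; within the scatter). For compound 3 the estimated value is 3500 nM, with an expected range of 1500 nM to 8000 nM.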

Compound 3, half-maximal inhibitory concentration: 4000 nM
Estimate against measurement, compound 3: 1.1-fold (0.06 log units) below; measured number inside the range.
By their numbers in this assay, from the lowest: compounds 1, 2 and 3 (each within the scatter of the next).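

In this assay, fluoro in place of chloro gives a 1.3-fold higher number from compound 2 to compound 3 (0.12 log units; within the scatter), and fluoro in place of bromo gives a 1.3-fold higher number from compound 1 to compound 3 (0.12 log units; within the scatter). Both steps lie within the scatter, so the three halogens on this aromatic carbon cannot be told apart in this series, and the exchange now spans fluoro as well as chloro and bromo. Nothing available bears on why these compounds stand level.

On these data alone, whether this position responds to anything other than a halogen stays open, for example an amine, a methoxy group or a carboxylic acid on the same carbon. Also open, as far as these compounds go, is whether the halogen exchange stays this flat when the nitro group of the shared core is replaced by a nitrile.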